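The source may report more compounds than this note shows. Statements on the series, on what has been measured and on what is new or still open speak of the compounds shown alone.

Measured so far in a functional assay on Jurkat cells (Homo sapiens) for cytotoxicity, read by luminescence and CellTiter-Glo, with a stated time of 3 days; on this read-out lower numbers stand for stronger inhibition and higher numbers for weaker inhibition:
- compound 1 (`O=C(Nc1ccc(C(F)(F)F)cc1)c1cc(Cl)ccc1O`): 710 nM
- compound 2 (`O=C(Nc1cc(C(F)(F)F)cc(C(F)(F)F)c1)c1ccc(Br)cc1O`): 930 nM
- compound 3 (`N#Cc1cc(Cl)ccc1NC(=O)c1ccc2cccnc2c1O`): 170 nM

Compound 1 at 710 nM lies within the scatter of compound 2 at 930 nM. Compound 3 at 170 nM gives a lower number than compound 1, and that gap lies beyond the scatter.

The next compound to be read is compound 4 (`O=C(Nc1ccc(C(F)(F)F)cc1)c1cc(F)ccc1O`). It keeps the core of compound 1 and carries fluoro in place of chloro on an aromatic carbon, para to a hydroxy group and meta to a large group (fluoro in place of chloro on an aromatic carbon).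

Going by the values given here, no two measured compounds differ in one place only, so the series does not yet show what a single exchange of this kind does in this assay. The three values give no direct guide to its size or direction. The starting point is therefore compound 1 at 710 nM, and a modest move towards a higher number, meaning weaker inhibition, is expected. The expected change is a 1.8-fold higher number from compound 1 to compound 4 (0.26 log units; within the scatter), which may not clear the scatter by much. For compound 4 the estimate is 1300 nM, with an expected range of 550 nM to 3500 nM.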

Compound 4, half-maximal inhibitory concentration: 580 nM
For compound 4 the middle estimate is 2.2-fold (0.35 log units) above the measured one, within the range that was stated.
By their numbers in this assay, from the lowest: compound 3; then compounds 4, 1 and 2 (each within the scatter of the next).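

In this assay, going by these compounds alone, fluoro in place of chloro on the aromatic carbon para to a hydroxy group and meta to a large group gives a 1.2-fold lower number from compound 1 to compound 4 (0.09 log units; within the scatter), and this is the first exchange that can be read in one place only. Within the data shown here, on the core of compound 1, this position therefore takes either of these two halogens with no difference beyond the scatter, so the read-out does not separate chloro from fluoro here, and the earlier compounds, which all differ in more than one place, could not show this. No measurement on these compounds bears on why the two halogens read alike.

A single step between two halogens leaves open what this position does with a group of another kind, such as an amine, a carboxylic acid, a methoxy group or plain hydrogen, and whether anything there moves the number beyond the scatter. It also leaves open whether the same exchange reads alike on a core other than that of compound 1.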